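A few compounds are considered here, and "the series" means these few. Any claim that something is new, unique, unknown or untested is made for them only; others in the source may bear on it.

Measured compounds:
- Compound 1, `COc1cccc(CNCCCNc2ccnc3cc(Oc4ccc(Cl)cc4)ccc23)c1O`: 14500 nM
- Compound 2, `COc1ccc(F)cc1CNCCCNc1ccnc2cc(C3CCCCC3)ccc12`: 4200 nM
- Compound 3, `Clc1ccc(Oc2ccc3c(NCCCNCc4ccco4)ccnc3c2)cc1`: 14500 nM

In a physicochemical assay for solubility, with a stated time of 18 h, at pH 7.4 (a lower number here means a less soluble compound, a higher number a more soluble compound), compound 1 gives 14500 nM, level with compound 3, and together these two have the highest numbers of the three; compound 2 lies furthest away, with a number that is lower beyond the scatter.

Compound 4, `COc1cccc(CNCCCNc2ccnc3cc(-c4ccc(C(C)(C)C)cc4)ccc23)c1O`, has not yet been measured. It differs from compound 1 in one place: 4-(tert-butyl)phenyl in place of 4-chlorophenoxy on an aromatic carbon. Among the measured compounds shown here, no measured step changes this position directly. For the measured compounds named here, the one measured step, no change at the digits printed from compound 1 to compound 3 (within the scatter), concerns the group on the saturated chain carbon bound to the amine nitrogen and lies elsewhere in the molecule, so it tells nothing about the aromatic carbon changed here. Compound 2 carries a saturated ring at the same aromatic position but also differs in the group on the chain carbon, so its lower number cannot be attributed to one place alone. With only this indirect hint, a drop beyond the scatter is expected, so that a 5.8-fold lower number from compound 1 to compound 4 (0.76 log units; beyond the scatter) is the estimated step. Compound 4 is therefore expected to give about 2500 nM, within a range from 600 nM to 8000 nM.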

Compound 4, solubility: 32000 nM
Compound 4: middle estimate off by 13-fold (1.11 log units), on the low side, outside the stated range (above it).
By their numbers in this assay, from the lowest: compound 2; then compounds 1 and 3 (each within the scatter of the next); then compound 4.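

In this assay, exchanging 4-chlorophenoxy for 4-(tert-butyl)phenyl on this aromatic carbon gives a 2.2-fold higher number from compound 1 to compound 4 (0.34 log units; beyond the scatter), the only measured step at this position among the compounds shown. The change removes the oxygen, the chlorine and the one hydrogen-bond acceptor of the leaving group and brings in a group of carbon only, yet the number rises, so in this pair a carbon-only group at this position does not come with a lower reading. No measurement is available to explain this rise, and its cause remains unknown.

This is a single pair on a single background, with the 2-hydroxy-3-methoxyphenyl group kept on the chain, so it sets no general trend, and the compounds shown leave open whether the same exchange would give a similar step with the furan-2-yl group of compound 3 on the chain. Also open, on these data alone, is how the reading in this assay would respond to a carboxylic acid, a morpholine or a simple amine on the aromatic ring at this same position.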